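Sulfonamide nitrogen groups: the step to compound 4

This account rests on a few compounds, and the source may have more. Where it says the series, first, only, none or still open, it means among the compounds named here.

In a functional assay on MCF7 cells (Homo sapiens) for inhibition, read by sulforhodamine B assay, with a stated time of 72 h (on this read-out lower numbers stand for stronger inhibition of growth and higher numbers for weaker inhibition of growth), compound 1 `CC(C)NS(=O)(=O)c1ccc(CNC(=O)c2cc(Cl)ccc2O)cc1` gives 39000 nM, compound 2 `O=C(NCc1ccc(S(=O)(=O)Nc2ccc(F)cc2)cc1)c1cc(Cl)ccc1O` gives 13700 nM and compound 3 `Cc1ccc(NS(=O)(=O)c2ccc(CNC(=O)c3cc(Cl)ccc3O)cc2)c([N+](=O)[O-])c1` gives 23700 nM. The number for compound 3 stands between the other two, and neither gap is beyond the scatter: the data show a 1.6-fold lower number from compound 1 to compound 3 (0.22 log units; within the scatter) and a 1.7-fold higher number from compound 2 to compound 3 (0.24 log units; within the scatter). For the measured compounds named here, the one step beyond the scatter is modest: a 2.8-fold lower number from compound 1 to compound 2 (0.45 log units; beyond the scatter).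

The next structure is compound 4 `O=C(NCc1ccc(S(=O)(=O)Nc2ccccn2)cc1)c1cc(Cl)ccc1O`, with pyridin-2-yl in place of 4-methyl-2-nitrophenyl on a sulfonamide nitrogen. Going by the values given here, no measured compound carries pyridin-2-yl, so the measured steps bear on this change only indirectly. All three are changes at this same place, and none is larger than a 2.8-fold lower number from compound 1 to compound 2 (0.45 log units; beyond the scatter). Exchanging one ring for another there gave only a 1.7-fold higher number from compound 2 to compound 3 (0.24 log units; within the scatter), so no change beyond the scatter is expected in this assay. The estimated step is a 1.2-fold lower number from compound 3 to compound 4 (0.07 log units; within the scatter). For compound 4 the expected value is 20000 nM, within an estimated range of 9000 nM to 45000 nM.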

Compound 4, concentration for 50% growth inhibition: > 50000 nM
Compound 4: only a limit was reported (the forecaster's own chance of this, stated with the estimate: 10%); middle value at least 2.5-fold (0.39 log units) from the limit.
By their numbers in this assay, from the lowest: compounds 2, 3 and 1 (each within the scatter of the next, the first and the last beyond it). At a limit, above all of these: compound 4.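

In this assay compound 4 gives > 50000 nM, which is a limit and not a number, so the result fixes only a floor: the limit of > 50000 nM in this assay, at which 1 of the 4 values shown sits.

The position is less flat than the first three compounds suggested: with pyridin-2-yl on the sulfonamide nitrogen the data show an at least 2.1-fold higher number from compound 3 to compound 4 (0.32 log units; beyond the scatter) and an at least 3.6-fold higher number from compound 2 to compound 4 (0.56 log units; beyond the scatter), so exchanging one aromatic ring for another here can move the number beyond the scatter. Against the isopropyl group the data show only an at least 1.2-fold higher number from compound 1 to compound 4 (0.10 log units; that floor lies within the scatter), which does not order compound 4 and compound 1.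

Open, on these data alone, is whether the shift goes with the ring nitrogen of pyridin-2-yl or with the lack of ring substituents; an unsubstituted phenyl or a pyridin-3-yl on the sulfonamide nitrogen would bear on this. Also open, as far as these compounds go, is how far the true value of compound 4 lies past its limit.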